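Swapping chloro for nitro on an aromatic carbon

The compounds below may be only part of what the source reports. "The series", "measured", "known", "first", "only" and "open" are said of these compounds alone.

In a functional assay on Raji cells (Homo sapiens) for cytotoxicity, read by CCK-8 assay, with a stated time of 24 h (on this read-out higher numbers stand for weaker inhibition and lower numbers for stronger inhibition), compound 1 `C=CC(=O)N1C(=O)CC(c2ccc(C)cc2)Sc2ccccc21` gives 75500 nM and compound 2 `C=CC(=O)N1C(=O)CC(c2ccc(Cl)cc2)Sc2ccccc21` gives 18400 nM, the lower of the two numbers and so the stronger inhibition. Compound 3 `C=CC(=O)N1C(=O)CC(c2ccc([N+](=O)[O-])cc2)Sc2ccccc21` has not yet been measured. It shares its core with compound 2 and differs in one place, with nitro in place of chloro on an aromatic carbon. Going by the values given here, only one measured step bears on this change, also a swap on an aromatic carbon: a 4.1-fold lower number from compound 1 to compound 2 (0.61 log units; beyond the scatter). That step is modest, though beyond the scatter. A single step sets no firm direction for a different swap, so only a small shift is expected in this assay, most likely within the scatter. The expected step is a 1.2-fold lower number from compound 2 to compound 3 (0.09 log units; within the scatter). Compound 3 is estimated at 15000 nM, with an expected range from 5000 nM to 45000 nM.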

Compound 3, half-maximal inhibitory concentration: 34800 nM
Beside the measured number, compound 3's estimate is 2.3-fold (0.37 log units) below it; the range from low to high includes it.
By their numbers in this assay, from the lowest: compounds 2 and 3 (each within the scatter of the next); then compound 1.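

Nitro in place of chloro gives a 1.9-fold higher number from compound 2 to compound 3 (0.28 log units; within the scatter) in this assay, so at this position, para to a large group, these two groups cannot be told apart on this read-out. Nitro in place of methyl gives a 2.2-fold lower number from compound 1 to compound 3 (0.34 log units; beyond the scatter), so the earlier drop on leaving methyl is no longer seen with chloro alone: among these three compounds, methyl gives the weakest inhibition, though only by a modest step. Nothing shown here offers a reason for these differences.

What the compounds shown leave open is how an amine, a carboxylic acid or a longer chain on this aromatic carbon would compare with chloro and nitro. Going by these compounds alone, with only three groups in one assay, they also leave open whether the lower numbers seen with chloro and nitro extend to any other group.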